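This account rests on a few compounds, and the source may have more. Where it says the series, first, only, none or still open, it means among the compounds named here.

Compound 1 `O=C(N1CCCN(Cc2ccc(OCc3ccccc3)cc2)CC1)n1cccn1`, compound 2 `CN(CCN(C)C(=O)n1cc(C#N)cn1)Cc1ccc(OCc2ccccc2)cc1` and compound 3 `Cc1cnn(C(=O)N(C)CCN(C)Cc2cccc(OCc3ccccc3)c2)c1` have all been tested in an assay on membranes from brain for binding affinity to neutral cholesterol ester hydrolase 1 (Mus musculus), read by fluorescence, with stated times of 1 h and 30 min; a higher number here means a weaker inhibitor, a lower number a stronger inhibitor. For compound 1 this assay reports only a limit, > 100000 nM, and not a number. Compound 2 likewise returns only a limit, > 100000 nM, in this assay. Compound 3 as well gives only a limit in this assay, > 100000 nM. Compound 3 therefore stands nowhere in particular among the three: all of them sit together at the limit of > 100000 nM in this assay, at which 3 of the 3 values shown sit, and no ordering between them can be read from such values.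

Compound 4 `CN(CCN(C)C(=O)n1cccn1)Cc1cccc(OCc2ccccc2)c1` has not yet been measured. It differs from compound 3 in a single place: hydrogen in place of methyl on an aromatic carbon. Among the measured compounds shown here, no step between two measured compounds is available, so no size can be read off for this kind of change. Because the three known values all rest at the limit of > 100000 nM in this assay, at which 3 of the 3 values shown sit, the step from compound 3 to compound 4 is expected to show no change beyond the scatter, and is most likely to end again at a limit. For compound 4 in this assay the estimate is 150000 nM, with a range from 50000 nM to 1000000 nM. The step this estimate implies is a step that the limit leaves unreadable from compound 3 to compound 4, expected to be flat.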

Compound 4, half-maximal inhibitory concentration: > 100000 nM
Compound 4 was reported as a limit; the forecaster's own chance of this, stated with the estimate: 85%; the middle value is on the limit's open side.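

Compound 3 and compound 4 both give only a limit in this assay, so no step can be read between them: the limit of > 100000 nM in this assay, at which 4 of the 4 values shown sit.

The compounds shown leave open how strongly any of them inhibits, and whether going from 4-methyl-1H-pyrazol-1-yl to 1H-pyrazol-1-yl matters at all.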